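Swapping the aryl group on the amide nitrogen

This account rests on a few compounds, and the source may have more. Where it says the series, first, only, none or still open, it means among the compounds named here.

Compound 1 `COc1ccc(-n2nc(C(=O)Nc3ccccc3OC)nc2-c2cc(OC)c(OC)c(OC)c2)cc1`: 52%
Compound 2 `COc1ccc(-n2nc(C(=O)Nc3ccccc3C)nc2-c2cc(OC)c(OC)c(OC)c2)cc1`: 19%

In a functional assay on the whole organism for inhibition, with Rattus norvegicus as the target, read by paw edema, with stated times of 30 min and 1 h, at a dose of 0.28 mmol/kg by the oral route (a higher number here means more inhibition at the dose given (going by the name of the read-out), a lower number less inhibition), compound 2 stands lowest of the two measured compounds, with compound 1 nearest at a number 33 percentage points lower from compound 1 to compound 2 (beyond the scatter). Compound 3 `COc1ccc(-n2nc(C(=O)Nc3ccc(C(F)(F)F)cc3)nc2-c2cc(OC)c(OC)c(OC)c2)cc1` differs from compound 2 by 4-(trifluoromethyl)phenyl in place of 2-methylphenyl on an amide-type nitrogen. Going by the values given here, the one measured step, a number 33 percentage points lower from compound 1 to compound 2 (beyond the scatter), concerns a different group at a different place on the same ring, so nothing measured bears directly on this change. The expectation is therefore loose: compound 3 is estimated at 30%, within 10% to 55%, meaning an expected step of a number 11 percentage points higher from compound 2 to compound 3 (beyond the scatter) that may or may not exceed the scatter.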

Compound 3, a percentage reported as inhibition, in the whole organism at one dose (the size of the read-out at that dose, not a potency): 48%
Compound 3: middle estimate off by 18 percentage points, on the low side; the measured number falls inside the stated range.
By their numbers in this assay, from the lowest: compound 2; then compounds 3 and 1 (each within the scatter of the next).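

In this assay, the step of a number 29 percentage points higher from compound 2 to compound 3 (beyond the scatter) shows that the low number of compound 2 is not shared by every aryl group lacking a methoxy, and 4-(trifluoromethyl)phenyl on the amide-type nitrogen restores much of the inhibition. The step of a number 4 percentage points lower from compound 1 to compound 3 (within the scatter) shows that this position does not depend on the 2-methoxyphenyl group for a number of this size. No measurement here offers a reason for either step.

The change from compound 2 to compound 3 alters both the group and its place on the ring, so the effect of each remains unseparated. Going by these compounds, whether 4-methylphenyl, 2-(trifluoromethyl)phenyl or an aryl group carrying an amine would behave similarly remains open.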